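Swapping the Amine Substituent on the Aryl Amide of Compound 1

The source may hold more compounds than are shown below. What is called first, only, known or untested is meant among the compounds shown, and "the series" means these compounds.

Compound 1 `CN(C)CCN(CCN(C)C)c1cccc(C(=O)N2CCc3ccc(OS(N)(=O)=O)cc3C2)c1` stands lowest among the three measured compounds: in an assay on HEK293 cells for inhibition of Steryl-sulfatase (Homo sapiens), tested at 1 uM (on this read-out lower numbers stand for a weaker effect and higher numbers for a stronger effect at the one concentration tested), compound 1 gives 17.1%, while compound 2 `CN(CCCN1CCCCC1)c1ccc(C(=O)N2CCc3ccc(OS(N)(=O)=O)cc3C2)cc1` gives 40.7% and compound 3 `NS(=O)(=O)Oc1ccc2c(c1)CN(C(=O)c1ccc(N3CCCCC3)cc1)CC2` gives 38.3%. Among the compounds with values here, the step of a number 2.4 percentage points lower from compound 2 to compound 3 (within the scatter) is the one measured change of the same kind, a swap of one amine substituent for another on an aromatic carbon. Compound 4 `CCN(Cc1ccccn1)c1cccc(C(=O)N2CCc3ccc(OS(N)(=O)=O)cc3C2)c1` differs from compound 1 by ethyl((pyridin-2-yl)methyl)amino in place of bis(2-(dimethylamino)ethyl)amino on an aromatic carbon, on an aromatic carbon of a six-membered aromatic ring of carbon only, meta to a large group. Because a number 2.4 percentage points lower from compound 2 to compound 3 (within the scatter) stayed within the scatter, a step of a number 7.9 percentage points higher from compound 1 to compound 4 (within the scatter) is expected, with a modest rise as the likelier direction. Compound 4 is therefore estimated at 25%, between 10% and 45%.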

Compound 4, a percentage reported as inhibition, at one concentration (the size of the read-out at that concentration, not a potency): 19.9%
For compound 4 the middle estimate is 5.1 percentage points above the measured one, within the range that was stated.
By their numbers in this assay, from the lowest: compounds 1 and 4 (each within the scatter of the next); then compounds 3 and 2 (each within the scatter of the next).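

In this assay, putting ethyl((pyridin-2-yl)methyl)amino in place of bis(2-(dimethylamino)ethyl)amino, on an aromatic carbon meta to a large group, gives a number 2.8 percentage points higher from compound 1 to compound 4 (within the scatter). At this place, then, a substituent with a six-membered aromatic ring and one with no ring cannot be told apart on this read-out. Nothing available explains this result. Still open, going by these compounds, is whether a morpholin-4-yl group or a carboxylic acid at this same place would shift the number beyond the scatter.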